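A few compounds are considered here, and "the series" means these few. Any claim that something is new, unique, unknown or untested is made for them only; others in the source may bear on it.

Compound 2 `N#Cc1ccc(Nc2nccc(N(CC3CCCC3)c3c(F)cc(-c4ccc(C#N)cc4)cc3F)n2)cc1` carries a cyclopentylmethyl chain on the nitrogen that joins its two aromatic parts. In an ADME assay on MT4 cells (Homo sapiens) for cytotoxicity, read by MTT assay, with a stated time of 5 days (a lower number here means that less compound is tolerated, a higher number that more compound is tolerated), compound 2 reaches only the limit of the measurement, > 247000 nM, so no exact number is known for it. Its closest measured neighbour, compound 1 `CCCN(c1ccnc(Nc2ccc(C#N)cc2)n1)c1c(F)cc(-c2ccc(C#N)cc2)cc1F`, carries a propyl chain at the same place and gives 212000 nM in this assay. The step of an at least 1.1-fold higher number from compound 1 to compound 2 (0.06 log units; that floor lies within the scatter) is therefore known only as a floor, and that floor lies within the scatter of repeated measurements; it rests on (the limit of > 247000 nM in this assay, at which 1 of the 2 values shown sits).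

Compound 3 `C=CCN(c1ccnc(Nc2ccc(C#N)cc2)n1)c1c(F)cc(-c2ccc(C#N)cc2)cc1F` is the next step from compound 2: vinyl in place of cyclopentyl on a saturated chain carbon bound to a nitrogen on an aromatic ring. The chain thus becomes shorter than in either measured compound, while the rest of the molecule stays the same. Going by the values given here, the only measured step at this position, from compound 1 to compound 2, shows no change beyond the scatter, so the step of an at least 1.2-fold lower number from compound 2 to compound 3 (0.09 log units; that floor lies within the scatter) is expected to stay small as well, with compound 3 estimated near compound 1. Compound 3 is thus expected to give about 200000 nM in this assay, somewhere between 100000 nM and 300000 nM.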

Compound 3, half-maximal cytotoxic concentration: 249000 nM
Compound 3: the middle estimate sits 1.2-fold (0.10 log units) below what was measured; low and high end bracket the measured number.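

Compound 3 is the only one of the three with a double bond outside aromatic rings, and its allyl chain replaces the propyl chain of compound 1 at the same place on the nitrogen. In this assay this change gives a 1.2-fold higher number from compound 1 to compound 3 (0.07 log units; within the scatter), so the two compounds cannot be told apart, and a double bond in this chain shows no readable effect on how much compound the cells tolerate. This is the first comparison at this position with an exact number on both sides, whereas the step from compound 2 to compound 3 cannot be read, because compound 2 stands only at a limit: the limit of > 247000 nM in this assay, at which 1 of the 3 values shown sits.

All three chains shown at this position are made of carbon alone, so it stays open whether an amine or a carboxylic acid on the chain would leave the tolerated amount just as it is. Going by these compounds, it also stays open whether a longer straight chain would fit the same picture, and how compound 2 truly compares with the other two remains unknown.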